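Swapping a Hydroxyalkyl Chain on an Azido Nucleoside

A few compounds are considered here, and "the series" means these few. Any claim that something is new, unique, unknown or untested is made for them only; others in the source may bear on it.

This study reports an ADME assay on CCRF-CEM cells (Homo sapiens) for cytotoxicity, with a stated time of 5 days; a higher number here means a weaker inhibitor, a lower number a stronger inhibitor. Compound 1 `[N-]=[N+]=N[C@H]1C[C@H](n2cnc3c(NCCCCCO)nc(N)nc32)O[C@@H]1CO` carries a 5-hydroxypentyl group on a nitrogen on an aromatic ring. In this assay compound 1 reaches only a limit of the assay, > 100000 nM, so no number is known for it. Compound 3 `COc1nc(Cl)nc2c1ncn2[C@H]1C[C@H](N=[N+]=[N-])[C@@H](CO)O1` likewise stops at a limit in this assay, giving > 100000 nM. Compound 2 `[N-]=[N+]=N[C@H]1C[C@H](n2cnc3c(N)nc(F)nc32)O[C@@H]1CO` is the one of the three with a measured number: in this assay compound 2 gives 30100 nM. Compound 1 therefore stands at the weak end of what the assay can report, as the limit of > 100000 nM in this assay, at which 2 of the 3 values shown sit, shows.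

Compound 4 `CC(C)(CO)Nc1nc(N)nc2c1ncn2[C@H]1C[C@H](N=[N+]=[N-])[C@@H](CO)O1` differs from compound 1 in a single place: 1-(hydroxymethyl)-1-methylethyl in place of 5-hydroxypentyl on a nitrogen on an aromatic ring. Going by the values given here, no measured pair of compounds in this set changes only that group, so there is no measured step to lean on. Since compound 1 already sits at the limit of > 100000 nM in this assay, at which 2 of the 3 values shown sit, the change to a shorter, branched hydroxyl-bearing group is expected to leave the readout close to the same limit, and the step of a number no higher from compound 1 to compound 4 (the limit leaves the size open) is expected to be none beyond the scatter. Compound 4 is estimated at 100000 nM, with a likely range from 30000 nM to 300000 nM.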

Compound 4, half-maximal inhibitory concentration: > 100000 nM
Compound 4: no number, only a limit; the forecaster's own chance of this, stated with the estimate: 70%; the middle value sits exactly at the limit.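

In this assay compound 4 gives > 100000 nM, which is a limit and not a number. Compound 1 stops at a limit too, so no step can be read between compound 1 and compound 4. On these data alone, whether either the 5-hydroxypentyl or the 1-(hydroxymethyl)-1-methylethyl compound has a measurable value in this assay, and how far apart those values lie, stays open.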